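Carboxy for methyl on the butylamide chain of compound 1

The compounds below may be only part of what the source reports. "The series", "measured", "known", "first", "only" and "open" are said of these compounds alone.

Measured so far:
compound 1, `CCCCNC(=O)C1C(C(=O)O)[C@@H]2CC[C@H]1O2` — 10000 nM
compound 2, `O=C(O)C1C(C(=O)Nc2ccc(CO)cc2)[C@H]2CC[C@@H]1O2` — 10000 nM

Compound 1 is examined in an ADME assay on MCF7 cells (Homo sapiens) for cytotoxicity, read by MTT assay, with a stated time of 72 h (a lower number here means a stronger inhibitor of growth, a higher number a weaker inhibitor of growth), together with compound 2. In this assay compound 1 gives 10000 nM, and compound 2 gives 10000 nM; the two values stand level with each other, within the scatter, so compound 1 sits at the same level as its nearest neighbour.

Compound 3 is `O=C(O)CCCNC(=O)C1C(C(=O)O)[C@@H]2CC[C@H]1O2` and has not yet been measured. It differs from compound 1 by carboxy in place of methyl on a saturated chain carbon, three bonds along the chain from an amide-type nitrogen.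

Among the measured compounds shown here, no step between measured compounds that differ in one place is available, so the size of this change has no precedent in the set. For the measured compounds named here, since both compound 1 and compound 2 sit at the same level, and no step here moves the number beyond the scatter, compound 3 is expected to stay near the level of compound 1, with a step of no change at the digits printed from compound 1 to compound 3 (within the scatter) expected to lie within the scatter. Compound 3 is therefore estimated at 10000 nM, in a range from 5000 nM to 20000 nM.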

Compound 3, concentration for 50% growth inhibition: 10000 nM
Compound 3: the middle estimate sits on the measured number at the digits printed, within the range that was stated.
By their numbers in this assay, from the lowest: compounds 1, 2 and 3 (each within the scatter of the next).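

In this assay, among the compounds shown here, carboxy in place of methyl gives no change at the digits printed from compound 1 to compound 3 (within the scatter) and so supplies the first step in this set that changes a single place. It shows that at this position, on a saturated chain carbon three bonds along the chain from an amide-type nitrogen, the swap of methyl for carboxy leaves the number level, which the earlier pair, differing in more than one place, could not show. Nothing measured here offers an explanation for this result.

The compounds shown leave open whether any change at this position moves the number, as the one step available stays within the scatter. An amine in place of the carboxy, or a longer chain carrying the carboxy, would be the next groups to compare with compound 1.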